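Adding a nitro group to compound 1

This account rests on a few compounds, and the source may have more. Where it says the series, first, only, none or still open, it means among the compounds named here.

Among the compounds with values here, in a functional assay on L6 cells (Rattus norvegicus) for cytotoxicity (a lower number here means a stronger inhibitor, a higher number a weaker inhibitor), compound 1 `Nc1nc(N)nc(N/N=C/c2cccs2)n1` gives 78200 nM, the only exact number so far. Compound 2 `Nc1nc(N)nc(N/N=C/c2ccco2)n1` reads > 400000 nM, which is a limit of the assay and not a number. Within the data shown here, the one measured step, an at least 5.1-fold higher number from compound 1 to compound 2 (0.70 log units; beyond the scatter), puts furan-2-yl in place of thiophen-2-yl, so it shows that this assay responds to a change of this ring but does not directly address an added group. Compound 3 `Nc1nc(N)nc(N/N=C/c2ccc([N+](=O)[O-])s2)n1` has nitro in place of hydrogen on an aromatic carbon. A step of similar size toward a lower number is expected, namely a 3.1-fold lower number from compound 1 to compound 3 (0.50 log units; beyond the scatter). For compound 3 the estimated value is 25000 nM, with an expected range of 3000 nM to 120000 nM.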

Compound 3, half-maximal inhibitory concentration: 11800 nM
For compound 3 the middle estimate is 2.1-fold (0.33 log units) above the measured one; low and high end bracket the measured number.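

The earlier compounds shown here only swapped one ring for another, whereas this result shows that the thiophen-2-yl ring can carry an added group on an aromatic carbon next to the ring sulfur. In this assay, nitro in place of hydrogen there gives a 6.6-fold lower number from compound 1 to compound 3 (0.82 log units; beyond the scatter), so the added group goes with a stronger effect on these cells rather than a loss. Nothing measured here explains why the number falls.

On these data alone, it remains open whether an amine or a carboxylic acid on that same carbon would lower the number too. Whether the drop is specific to nitro therefore cannot be judged from these compounds.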